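Linker swap on the oxadiazole arm: from phenoxy to anilinomethyl

The compounds below may be only part of what the source reports. "The series", "measured", "known", "first", "only" and "open" are said of these compounds alone.

Measured compounds and their values:
Compound 1, `CCc1ccccc1N(Cc1nnc(Cc2ccccc2)o1)S(=O)(=O)c1ccc(C)cc1`: 398 nM
Compound 2, `CCc1ccccc1N(Cc1nnc(Cc2ccc(OC)cc2)o1)S(=O)(=O)c1ccc(C)cc1`: 631 nM
Compound 3, `CCc1ccccc1N(Cc1nnc(Oc2ccc(OC)cc2)o1)S(=O)(=O)c1ccc(C)cc1`: 100 nM

The three measured compounds share one core and differ only in the group on the five-membered aromatic ring. In a functional assay on CHO cells for antagonist activity at prostaglandin E2 receptor EP1 subtype (Homo sapiens), read by FLIPR and calcium flux (a higher number here means a weaker inhibitor, a lower number a stronger inhibitor), compound 3 gives the lowest number of the three: compared with compound 1 the step is a 4.0-fold lower number from compound 1 to compound 3 (0.60 log units; beyond the scatter), and compared with compound 2 it is a 6.3-fold lower number from compound 2 to compound 3 (0.80 log units; beyond the scatter). Between compound 1 and compound 2 the step is a 1.6-fold higher number from compound 1 to compound 2 (0.20 log units; within the scatter), so the methoxy on its own makes no difference that can be trusted.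

Compound 4, `CCc1ccccc1N(Cc1nnc(CNc2ccc(OC)cc2)o1)S(=O)(=O)c1ccc(C)cc1`, has not been measured. It changes the arm of compound 3 as follows: ((4-methoxyphenyl)amino)methyl in place of 4-methoxyphenoxy on an aromatic carbon. Going by the values given here, the aryl ring is thus held by a two-atom link, as in compound 1 and compound 2, rather than by the single oxygen of compound 3. The two steps of a 4.0-fold lower number from compound 1 to compound 3 (0.60 log units; beyond the scatter) and a 6.3-fold lower number from compound 2 to compound 3 (0.80 log units; beyond the scatter) bear on this: both show that the shorter oxygen link sits lower than the two-atom link. Moving back to a two-atom link is therefore expected to raise the number, by roughly a 3.5-fold higher number from compound 3 to compound 4 (0.54 log units; beyond the scatter), toward the values of compound 1 and compound 2. Compound 4 is expected to give about 350 nM, with a likely range of 120 nM to 1000 nM.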

Compound 4, inhibition constant: 794 nM
Compound 4: middle estimate off by 2.3-fold (0.36 log units), on the low side; low and high end bracket the measured number.
By their numbers in this assay, from the lowest: compound 3; then compounds 1, 2 and 4 (each within the scatter of the next).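

In this assay, swapping the 4-methoxyphenoxy arm for ((4-methoxyphenyl)amino)methyl gives a 7.9-fold higher number from compound 3 to compound 4 (0.90 log units; beyond the scatter) and removes the advantage of the oxygen-linked arm at this position on the five-membered ring. The new arm brings a hydrogen-bond donor, yet a 1.3-fold higher number from compound 2 to compound 4 (0.10 log units; within the scatter) and a 2.0-fold higher number from compound 1 to compound 4 (0.30 log units; within the scatter) are both within the scatter, so compound 3 alone stands apart and the other three compounds cannot be placed in any order. Nothing available explains why the oxygen-linked arm gives the lowest number.

The compounds shown leave open whether the low number depends on the oxygen atom itself or on the shorter link, since the arm of compound 4 differs from that of compound 3 in both the linking atoms and their length. A sulfur atom or a directly attached amine nitrogen in place of that oxygen would separate these two readings, and a plain phenoxy arm would show whether the methoxy matters on the oxygen-linked series.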